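The source may report more compounds than this note shows. Statements on the series, on what has been measured and on what is new or still open speak of the compounds shown alone.

The measured compounds:

Compound 1, `Oc1cccc(-c2cc(-c3ccsc3)cc(-c3ccccc3O)n2)c1`. In a functional assay on HeLa cells (Homo sapiens) for cytotoxicity, read by CCK-8 assay (a higher number here means a weaker inhibitor, a lower number a stronger inhibitor), compound 1 reaches only the limit > 50000 nM, not a number.
Compound 2, `Oc1ccc(-c2cc(-c3ccsc3)cc(-c3ccccc3O)n2)cc1`. In this assay compound 2 likewise reaches only the limit > 50000 nM.
Compound 3, `Oc1cccc(-c2cc(-c3ccccn3)cc(-c3ccccc3O)n2)c1`. In this assay compound 3 gives 2020 nM.

Going by the values given here, compound 3 differs from compound 1 in its core by pyridin-2-yl in place of thiophen-3-yl on an aromatic carbon, and this is the one change with a readable size: an at least 24-fold lower number from compound 1 to compound 3 (1.39 log units; beyond the scatter). Between compound 1 and compound 2 the change is 4-hydroxyphenyl in place of 3-hydroxyphenyl on an aromatic carbon, but its step, a step that the two limits leave unreadable from compound 1 to compound 2, cannot be sized because of the limit of > 50000 nM in this assay, at which 2 of the 3 values shown sit.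

Compound 4, `Oc1ccc(-c2cc(-c3ccccn3)cc(-c3ccccc3O)n2)cc1`, is not yet measured. It differs from compound 3 by 4-hydroxyphenyl in place of 3-hydroxyphenyl on an aromatic carbon. This is the same kind of change as that from compound 1 to compound 2, though not the same: there it sits meta to a thiophen-3-yl group, here meta to a pyridin-2-yl group. Among the compounds with values here, the only earlier example gives no size, so the expectation rests on the result of compound 3, 2020 nM, and on the fact that the two compounds hold the same atoms joined differently. The step is expected to be small: a 1.5-fold higher number from compound 3 to compound 4 (0.17 log units; within the scatter). Compound 4 is estimated at 3000 nM, with a range from 800 nM to 15000 nM.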

Compound 4, half-maximal inhibitory concentration: > 50000 nM
Compound 4: a limit, no number; the forecaster's own chance of this, stated with the estimate: 15%; middle value at least 16-fold (1.22 log units) away from the limit.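

In this assay, 4-hydroxyphenyl in place of 3-hydroxyphenyl on the core bearing pyridin-2-yl gives an at least 24-fold higher number from compound 3 to compound 4 (1.39 log units; beyond the scatter), so two compounds with the same atoms, joined differently, are far apart on this core, and the printed size is only a minimum since one end of the step is a limit. The same change on the core bearing thiophen-3-yl, from compound 1 to compound 2, cannot be sized, and neither can the step from compound 2 to compound 4, because both ends of each step are limits: the limit of > 50000 nM in this assay, at which 3 of the 4 values shown sit. The change therefore has one readable size, on one core, and while compound 2 and compound 4 both end at a limit, this does not show that the change has the same effect on both cores, nor how large it is on the core of compound 1.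

The compounds shown leave open what replacing the hydroxyl of the 3-hydroxyphenyl group in compound 3 with an amine or a carboxylic acid would do in this assay. They also leave open whether pyridin-3-yl in place of pyridin-2-yl would keep the reading of compound 3, and whether the large step holds in any other cell line.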